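Nitro in place of methoxy: toxicity notes on the series

This account rests on a few compounds, and the source may have more. Where it says the series, first, only, none or still open, it means among the compounds named here.

Compound 1 `COc1ccc(Cc2nnc(Cn3nnc4ccccc43)o2)cc1` and compound 2 `O=[N+]([O-])c1ccc(Cc2nnc(Cn3nnc4ccccc43)o2)cc1` share one core and differ in a single place: nitro in place of methoxy on an aromatic carbon. Compound 3 `COc1ccc(-c2nnc(Cn3nnc4ccccc43)o2)cc1` carries the same methoxy group on a second core; how the two cores differ is not broken down here. Compound 4 `O=[N+]([O-])c1ccc(-c2nnc(Cn3nnc4ccccc43)o2)cc1` is the not yet measured partner of compound 3 and differs from it by nitro in place of methoxy on an aromatic carbon. The two place descriptions read the same word for word, so this is the same change made twice in the set.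

In an ADME assay on cells (Macrophage, Homo sapiens) for inhibition (on this read-out higher numbers stand for lower toxicity in this test and lower numbers for higher toxicity in this test), compound 1 gives only a limit, > 100000 nM. Compound 2 likewise gives only a limit in this assay, > 100000 nM. For compound 3 this assay again reports only a limit, > 100000 nM. The step that the two limits leave unreadable from compound 1 to compound 2 therefore cannot be sized; both of its ends sit at the limit of > 100000 nM in this assay, at which 3 of the 3 values shown sit. Every value shown stands at that limit, so no order among compounds 1, 2 and 3 can be drawn and no measurable toxicity appears anywhere in the set.

For compound 4 the expectation is that the read-out stays at the limit: the step expected is a number no higher from compound 3 to compound 4 (the limit leaves the size open), resting on a step that the two limits leave unreadable from compound 1 to compound 2 and on (the limit of > 100000 nM in this assay, at which 3 of the 3 values shown sit). Compound 4 is estimated at 100000 nM, with a range from 50000 nM to 300000 nM, and is expected most likely to be reported once more only as a limit.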

Compound 4, half-maximal cytotoxic concentration: > 100000 nM
Compound 4: no number, only a limit; the forecaster's own chance of this, stated with the estimate: 85%; the middle value lies on the limit itself.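

Compound 4, like compound 3, gives only a limit in this assay, so no new step can be read from compound 3 to compound 4, and the four compounds fall in no order: the limit of > 100000 nM in this assay, at which 4 of the 4 values shown sit. The compounds shown leave open how far the cytotoxic concentrations of compound 1, compound 2, compound 3 and compound 4 lie past that limit, and whether nitro in place of methoxy shifts them on either core.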